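Moving the fluorine around the phenyl ring of compound 1

The source may report more compounds than this note shows. Statements on the series, on what has been measured and on what is new or still open speak of the compounds shown alone.

Compound 1 `N#CC1=C(N)OC(c2c[nH]c3ccccc23)=C(C#N)C1c1ccccc1F`: "not active" (no number reported)
Compound 2 `COc1ccc(C2C(C#N)=C(N)OC(c3c[nH]c4ccccc34)=C2C#N)cc1`: 20%
Compound 3 `N#CC1=C(N)OC(c2c[nH]c3ccccc23)=C(C#N)C1c1ccccc1Cl`: 10.4%

Of the compounds shown here, three sharing one core have been measured in a functional assay, tested at 100 ug/mL; a higher number here means a stronger effect of the compound at the concentration tested, a lower number a weaker effect. Compound 1 was reported as "not active" (no number reported), with no number given, so it cannot be placed on the scale with compound 2 and compound 3. Compound 2 gives 20% and compound 3 gives 10.4%; the step of a number 9.6 percentage points lower from compound 2 to compound 3 (within the scatter) is within the scatter, so these two cannot be ordered.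

Compound 4 `N#CC1=C(N)OC(c2c[nH]c3ccccc23)=C(C#N)C1c1ccc(F)cc1` is not yet measured. It differs from compound 1 in that (4-fluorophenyl in place of 2-fluorophenyl on a saturated ring carbon). Among the compounds with values here, the one measured step that bears on it, a number 9.6 percentage points lower from compound 2 to compound 3 (within the scatter), also exchanges the aryl group on the saturated ring carbon and was within the scatter. Since every measured value is low or absent, compound 4 is expected to remain in the same low range, with no step beyond the scatter. The value of compound 4 is therefore estimated at 10%, between 0% and 25%, with a fair chance that it is reported only as not active.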

Compound 4, a percentage reported as activity, at one concentration (the size of the read-out at that concentration, not a potency): 16.2%
Compound 4: middle estimate off by 6.2 percentage points, on the low side, within the range that was stated.
By their numbers in this assay, from the lowest: compounds 3, 4 and 2 (each within the scatter of the next).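

In this assay the exchange of 2-fluorophenyl for 4-fluorophenyl on the saturated ring carbon turns a report without a number into a measured figure, as compound 1 stands at "not active" (no number reported) and compound 4 at 16.2% in the same test. Compared with the other measured compounds, the data show a number 5.8 percentage points higher from compound 3 to compound 4 (within the scatter) and a number 3.8 percentage points lower from compound 2 to compound 4 (within the scatter) as the two readable steps, so 4-fluorophenyl, 2-chlorophenyl and 4-methoxyphenyl cannot be told apart at this position. Nothing available here explains these results.

Going by these compounds, compound 1 carries no number, so how far it lies from compound 4 stays open. Also open, on these data alone, is whether a carboxylic acid or an amine on this phenyl ring would give a step beyond the scatter.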